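One Extra Methyl: What to Expect for Compound 4

A few compounds are considered here, and "the series" means these few. Any claim that something is new, unique, unknown or untested is made for them only; others in the source may bear on it.

Of the compounds shown here, three have been measured in a functional assay on the whole organism with Mus musculus as the target; on this read-out higher numbers stand for an effect only at larger amounts of compound and lower numbers for an effect already at smaller amounts; each result is a limit of the assay rather than a number.
Compound 1 `CCN(c1ccncc1)n1cccc1Cl` gives > 20 mg/kg.
Compound 2 `CCCN(c1ccncc1)n1cccc1Cl` gives > 20 mg/kg.
Compound 3 `CN(c1ccncc1)n1cccc1CO` gives > 20 mg/kg.

Compound 2 differs from compound 1 by methyl in place of hydrogen on a saturated chain carbon, two bonds along the chain from a nitrogen on an aromatic ring, and the step is a step that the two limits leave unreadable from compound 1 to compound 2. The difference between the cores of compound 1 and compound 3 is not broken down here. Compound 4 `CC(O)c1cccn1N(C)c1ccncc1` differs from compound 3 by methyl in place of hydrogen on a saturated chain carbon bound to an aromatic carbon and an oxygen on a saturated carbon. This is the same kind of change as from compound 1 to compound 2, but at another place: there the carbon sat two bonds along the chain from a nitrogen on an aromatic ring, here it is bound to an aromatic carbon and an oxygen on a saturated carbon. All the evidence rests on (the limit of > 20 mg/kg in this assay, at which 3 of the 3 values shown sit). The step is expected to be a step that the limit leaves unreadable from compound 3 to compound 4, because the earlier step that the two limits leave unreadable from compound 1 to compound 2 gave no readable size. Compound 4 is therefore expected to give about 30 mg/kg, between 10 mg/kg and 100 mg/kg, most likely again only a limit.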

Compound 4, dose for half-maximal effect: > 20 mg/kg
Compound 4: only a limit was reported; the forecaster's own chance of this, stated with the estimate: 75%; the middle value lies beyond the limit too.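

No step can be read between compound 3 and compound 4: both results are only limits of the assay. In this assay the compounds shown leave open at what dose any of them reaches half-maximal effect.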